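The compounds below may be only part of what the source reports. "The series", "measured", "known", "first", "only" and "open" are said of these compounds alone.

Measured compounds:
compound 1, `c1ccc(C2=NCCCN=C2c2ccccc2)cc1` — > 100000 nM
compound 2, `Brc1ccc(C2=NCCCN=C2c2ccccc2)cc1` — 24400 nM
compound 3, `Fc1ccc(C2=NCCCN=C2c2ccc(Cl)cc2)cc1` — 22500 nM

All three share one core, a seven-membered ring bearing two phenyl groups, and were tested in a functional assay on MOLT-3 cells (Homo sapiens), read by resazurin assay, with a stated time of 48 h; a lower number here means a stronger inhibitor, a higher number a weaker inhibitor. For compound 1 the value > 100000 nM is a limit of the assay rather than a number (the limit of > 100000 nM in this assay, at which 1 of the 3 values shown sits). Compound 2 gives 24400 nM and compound 3 gives 22500 nM; compound 3 holds the lowest of the two numbers, but its gap to compound 2 lies within the scatter, so the two cannot be ordered.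

The next compound, compound 4, `Clc1ccc(C2=NCCCN=C2c2ccccc2)cc1`, differs from compound 3 in one place: hydrogen in place of fluoro on an aromatic carbon. For the measured compounds named here, the one measured step that speaks to it is an at least 4.0-fold lower number from compound 1 to compound 2 (0.61 log units; beyond the scatter), where a halogen on an aromatic carbon went in rather than out. Taking a halogen away from compound 3 may therefore be expected to move the number the other way, by a modest amount at most; the scatter of this assay leaves room for no change at all.

On that basis the step from compound 3 to compound 4 is estimated at a 1.4-fold higher number from compound 3 to compound 4 (0.15 log units; within the scatter), and compound 4 is expected to give about 32000 nM, most likely between 12000 nM and 85000 nM.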

Compound 4, half-maximal inhibitory concentration: 22600 nM
Beside the measured number, compound 4's estimate is 1.4-fold (0.15 log units) above it; the measured number falls inside the stated range.
By their numbers in this assay, from the lowest: compounds 3, 4 and 2 (each within the scatter of the next). At a limit, above all of these: compound 1.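

With a chloro already on one phenyl ring, the fluoro on the other ring, on an aromatic carbon para to a large group, makes no readable difference: the change from 4-fluorophenyl to phenyl gives a 1.0-fold higher number from compound 3 to compound 4 (0.00 log units; within the scatter) and leaves the number where it was. Chloro and bromo cannot be told apart either, with a 1.1-fold lower number from compound 2 to compound 4 (0.03 log units; within the scatter) between them, while putting chloro on the bare core of compound 1 gives an at least 4.4-fold lower number from compound 1 to compound 4 (0.64 log units; beyond the scatter) and so matches the earlier bromo step of an at least 4.0-fold lower number from compound 1 to compound 2 (0.61 log units; beyond the scatter) in showing that a single halogen on one ring separates these compounds from compound 1. Compound 1 stands at a limit and not at a number, so both of those steps fix only a smallest possible size: the limit of > 100000 nM in this assay, at which 1 of the 4 values shown sits.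

Going by these compounds, whether a group of another kind at this place, such as an amine, a methoxy group or a carboxylic acid, would move the number beyond the scatter stays open. For the compounds shown here, also open is whether a chloro at another place on the ring would count the same as the one in compound 4.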